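Replacing 3-hydroxypiperidin-1-yl in compound 2

The compounds below may be only part of what the source reports. "The series", "measured", "known", "first", "only" and "open" are said of these compounds alone.

Measured so far in a functional assay on NCI-H460 cells (Homo sapiens) for inhibition, read by sulforhodamine B assay, with a stated time of 72 h (on this read-out lower numbers stand for stronger inhibition and higher numbers for weaker inhibition), with these results:
- compound 1 `CC(C)c1cc(-n2nncc2-c2ccc(CN3CCN(c4ccccc4)CC3)cc2)c(O)cc1O` gives 520 nM
- compound 2 `CCNC(=O)c1nnn(-c2cc(C(C)C)c(O)cc2O)c1-c1ccc(CN2CCCC(O)C2)cc1` gives 62 nM
- compound 3 `CCNC(=O)c1nnn(-c2cc(C(C)C)c(O)cc2O)c1-c1ccc(CN2CCC(N(C)C)CC2)cc1` gives 120 nM

Compound 2 shares the low end of the three numbers with compound 3, and compound 1 has a much higher number. Next in view is compound 4 `CCNC(=O)c1nnn(-c2cc(C(C)C)c(O)cc2O)c1-c1ccc(CNCC2CCCCC2)cc1` with this change: (cyclohexylmethyl)amino in place of 3-hydroxypiperidin-1-yl on a saturated chain carbon bound to an aromatic carbon. In words, (cyclohexylmethyl)amino stands in place of 3-hydroxypiperidin-1-yl on a saturated chain carbon bound to an aromatic carbon.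

For the measured compounds named here, only one measured step bears on this, as it replaces the same group: a 1.9-fold higher number from compound 2 to compound 3 (0.29 log units; within the scatter). Going by the values given here, that step is small, but its entering group, 4-(dimethylamino)piperidin-1-yl, is not the one in compound 4, so it is only a loose guide. Among the compounds with values here, compound 1 differs from compound 2 in more than one place and gives no clean step. No step beyond the scatter is expected, and the expected step is a 1.6-fold higher number from compound 2 to compound 4 (0.21 log units; within the scatter). For compound 4 in this assay the estimated value is 100 nM, with an expected range of 35 nM to 280 nM.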

Compound 4, half-maximal inhibitory concentration: 2.1 nM
Estimate against measurement, compound 4: 48-fold (1.68 log units) above; the whole stated range lies above it.
By their numbers in this assay, from the lowest: compound 4; then compounds 2 and 3 (each within the scatter of the next); then compound 1.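

In this assay, for the compounds shown here, the position on a saturated chain carbon bound to an aromatic carbon turns out to be highly sensitive to the group it carries: (cyclohexylmethyl)amino in place of 3-hydroxypiperidin-1-yl gives a 30-fold lower number from compound 2 to compound 4 (1.47 log units; beyond the scatter), whereas the only earlier step here stayed small, at a 1.9-fold higher number from compound 2 to compound 3 (0.29 log units; within the scatter). The same entering group in place of 4-(dimethylamino)piperidin-1-yl gives a 57-fold lower number from compound 3 to compound 4 (1.76 log units; beyond the scatter), so the large drop appears against both piperidine groups shown. No measurement at hand accounts for the size of these steps.

The change replaces the piperidine ring with a carbon-only ring and an open amino link in a single move, and the compounds shown do not separate these two features. Cyclohexylamino, benzylamino and (2-cyclohexylethyl)amino at the same place would bear on that question.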